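The source may report more compounds than this note shows. Statements on the series, on what has been measured and on what is new or still open speak of the compounds shown alone.

Values in a functional assay on A498 cells (Homo sapiens) for inhibition, read by sulforhodamine B assay, with a stated time of 48 h; on this read-out lower numbers stand for stronger inhibition of growth and higher numbers for weaker inhibition of growth:

- Compound 1 `Cc1ccc(NC(=O)/C=C/c2ccccc2)c(C(N)=O)c1`: 5560 nM
- Compound 2 `NC(=O)c1cc(Br)ccc1NC(=O)/C=C/c1ccccc1`: 1700 nM
- Compound 3 `NC(=O)c1cc(I)ccc1NC(=O)/C=C/c1ccccc1`: 2700 nM

Compound 3, the iodo member, gives 2700 nM. It cannot be told apart from the bromo member, with a 1.6-fold higher number from compound 2 to compound 3 (0.20 log units; within the scatter). It does stand apart from the methyl member, with a 2.1-fold lower number from compound 1 to compound 3 (0.31 log units; beyond the scatter).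

Compound 4 `NC(=O)c1cc(I)ccc1NC(=O)/C=C/c1ccccc1Cl` has chloro in place of hydrogen on an aromatic carbon, so that phenyl becomes 2-chlorophenyl: chloro in place of hydrogen on an aromatic carbon. Among the compounds with values here, none of the measured steps touches that phenyl. All three exchange the methyl, bromo or iodo group instead, so they bear on this change only indirectly. The largest of them, a 3.3-fold lower number from compound 1 to compound 2 (0.51 log units; beyond the scatter), is modest, which gives a rough idea of how far a single-atom exchange has moved the numbers in this small set. A step beyond the scatter is therefore not expected in this assay, and no direction can be argued from these data. The expected step is a 1.2-fold lower number from compound 3 to compound 4 (0.09 log units; within the scatter). For compound 4 the estimated value is 2200 nM, with an expected range of 750 nM to 6000 nM.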

Compound 4, concentration for 50% growth inhibition: 880 nM
Beside the measured number, compound 4's estimate is 2.5-fold (0.40 log units) above it, and the stated range covers the measured number.
By their numbers in this assay, from the lowest: compounds 4, 2 and 3 (each within the scatter of the next, the first and the last beyond it); then compound 1.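

In this assay, chloro in place of hydrogen, ortho to a large group, turns the phenyl into 2-chlorophenyl and gives a 3.1-fold lower number from compound 3 to compound 4 (0.49 log units; beyond the scatter). Within the data shown here, the earlier compounds varied only the methyl, bromo or iodo group, so this is the first sign that the phenyl is also a place where a single-atom exchange can move the number beyond the scatter, here towards stronger inhibition of growth, though the step is only modest. Nothing available explains why the number falls with this change.

The compounds shown leave open whether chloro would give a similar step with bromo or methyl in place of the iodo group. They also leave open whether fluoro, methoxy or an amine at this same place would move the number in the same direction.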